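Trifluoromethoxy for trifluoromethyl in compound 1

The source may report more compounds than this note shows. Statements on the series, on what has been measured and on what is new or still open speak of the compounds shown alone.

Compound 1 `O=C(O)CCNC(=O)c1ccc(CN(c2ccc(Cl)cc2)c2nc(-c3ccc(C(F)(F)F)cc3)cs2)cc1` gives 1.33 h in an in vivo ADME assay on the whole organism (strain beagle) for metabolic stability, with Canis familiaris (Canis lupus familiaris) as the target, at a dose of 0.25 mg/kg by the intravenous route (on this read-out lower numbers stand for a shorter-lived compound and higher numbers for a longer-lived compound), the lowest of the three numbers in hand. Compound 2 `O=C(O)CCNC(=O)c1ccc(CN(c2ccc(C(F)(F)F)cc2)c2nc(-c3ccc(Cl)cc3)cs2)cc1` gives 1.73 h in this assay, within the scatter of compound 1. Compound 3 `O=C(O)CCNC(=O)c1ccc(CN(c2ccc(OC(F)(F)F)cc2)c2nc(-c3ccc(C(F)(F)F)cc3)cs2)cc1` gives 3.92 h, and the step of a 2.9-fold higher number from compound 1 to compound 3 (0.47 log units; beyond the scatter) is the only one beyond the scatter. Compound 4 `O=C(O)CCNC(=O)c1ccc(CN(c2ccc(Cl)cc2)c2nc(-c3ccc(OC(F)(F)F)cc3)cs2)cc1` differs from compound 1 by trifluoromethoxy in place of trifluoromethyl on an aromatic carbon. Within the data shown here, no measured pair changes that group; the nearest guide is a 2.9-fold higher number from compound 1 to compound 3 (0.47 log units; beyond the scatter), where trifluoromethoxy entered in place of chloro on another aromatic carbon of the shared core and gave a modest rise. A smaller gain, within or just beyond the scatter, is expected here. Compound 4 is therefore estimated at 2 h, with a range from 1 h to 4 h. That expected value means a step of a 1.5-fold higher number from compound 1 to compound 4 (0.18 log units; within the scatter).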

Compound 4, half-life: 1.1 h
Compound 4: middle estimate off by 1.8-fold (0.26 log units), on the high side; the measured number falls inside the stated range.
By their numbers in this assay, from the lowest: compounds 4, 1 and 2 (each within the scatter of the next); then compound 3.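

In this assay, trifluoromethoxy in place of trifluoromethyl at this position gives a 1.2-fold lower number from compound 1 to compound 4 (0.08 log units; within the scatter), so the two groups are not told apart here. The rise of a 2.9-fold higher number from compound 1 to compound 3 (0.47 log units; beyond the scatter) therefore does not carry over to this position, although there trifluoromethoxy replaced chloro rather than trifluoromethyl. Nothing in hand accounts for the contrast between the two positions. Open, as far as these compounds go, is whether a nitrile or a methoxy group at this position would read differently, and whether trifluoromethoxy on both aromatic rings would change the half-life.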